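Removing the trifluoromethyl group from compound 2

This account rests on a few compounds, and the source may have more. Where it says the series, first, only, none or still open, it means among the compounds named here.

Of the compounds shown here, two that share one core have been measured so far in a functional assay on SH-SY5Y cells (Homo sapiens) for antiproliferative activity, read by MTT assay, with a stated time of 72 h; on this read-out higher numbers stand for weaker inhibition and lower numbers for stronger inhibition. Compound 1 `FC(F)(F)c1ccc(COc2ccc(Nc3ncnc4cc5c(cc34)OCCOCCOCCO5)cc2)cc1` gives > 100000 nM, which is a limit of the assay and not a number. For the measured compounds named here, compound 2 `FC(F)(F)c1ccc(COc2cccc(Nc3ncnc4cc5c(cc34)OCCOCCOCCO5)c2)cc1` gives 20000 nM, and this is the only actual number available in this assay, so it has no measured number to be ranked against.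

The next compound, compound 3 `c1ccc(COc2cccc(Nc3ncnc4cc5c(cc34)OCCOCCOCCO5)c2)cc1`, has not yet been measured. It departs from compound 2 in a single place: hydrogen in place of trifluoromethyl on an aromatic carbon. Hydrogen stands in place of trifluoromethyl on an aromatic carbon, which turns the 4-(trifluoromethyl)benzyl group into benzyl.

Going by the values given here, no measured pair shows what this change does, so the expectation rests on a single anchor, compound 2 at 20000 nM. The estimated step is a 1.5-fold higher number from compound 2 to compound 3 (0.18 log units; within the scatter), which is expected to stay within the usual scatter of this assay, with no firm direction. For compound 3 the expected value is 30000 nM, with an estimated range from 10000 nM to 90000 nM.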

Compound 3, half-maximal inhibitory concentration: 22800 nM
For compound 3 the middle estimate is 1.3-fold (0.12 log units) above the measured one; the measured number falls inside the stated range.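

For the compounds shown here, the exchange of 4-(trifluoromethyl)benzyl for benzyl gives the first step that can be read in this assay: a 1.1-fold higher number from compound 2 to compound 3 (0.06 log units; within the scatter). On this carbon, para to a large group, compound 2 and compound 3 therefore cannot be told apart in this assay, so the trifluoromethyl group, with its four heavy atoms, can be replaced by a hydrogen atom without a difference that exceeds the usual scatter of the measurement. The value of compound 1 is a limit of the assay and not a number, and it takes no part in this step, which rests on two actual numbers: the limit of > 100000 nM in this assay, at which 1 of the 3 values shown sits.

Going by these compounds, whether another group on the same ring carbon, such as an amine, a carboxylic acid or a methoxy group, would separate from compound 2 and compound 3 stays open, as does whether the same exchange would read alike in the arrangement of compound 1. Also open, on these data alone, is what a longer chain in place of the benzyl group would do to the number in this assay.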